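The source may report more compounds than this note shows. Statements on the series, on what has been measured and on what is new or still open speak of the compounds shown alone.

Measured in an ADME assay for permeability, using PAMPA, with a stated time of 30 min, at pH 7.4; on this read-out lower numbers stand for lower permeability and higher numbers for higher permeability:

compound 1 `COc1ccc(F)cc1CNCCCNc1ccnc2cc(Cc3ccc(F)cc3Cl)ccc12` gives 23 10^-6 cm/s
compound 2 `COc1ccc(F)cc1CNCCCNc1ccnc2cc(CC3CCCCC3)ccc12` gives 23 10^-6 cm/s
compound 3 `COc1cccc(CNCCCNc2ccnc3cc(CC4CCCCC4)ccc23)c1O` gives 23 10^-6 cm/s

Compound 4 `COc1cccc(CNCCCNc2ccnc3cc(Cc4ccc(F)cc4Cl)ccc23)c1O` has not yet been measured in this assay. It differs from compound 3 in one place: 2-chloro-4-fluorophenyl in place of cyclohexyl on a saturated chain carbon bound to an aromatic carbon. The same change, in the same place, connects two measured compounds, compound 2 and compound 1: 2-chloro-4-fluorophenyl in place of cyclohexyl on a saturated chain carbon bound to an aromatic carbon. In this assay that step reads no change at the digits printed from compound 2 to compound 1 (within the scatter). The pair compound 3 and compound 4 shares a core that differs from the core of compound 2 and compound 1 in one place: 2-hydroxy-3-methoxyphenyl in place of 5-fluoro-2-methoxyphenyl on a saturated chain carbon bound to an amine nitrogen; in this assay the step of no change at the digits printed from compound 2 to compound 3 (within the scatter) is itself flat. All three measured compounds thus sit level with one another in this assay, and neither of the two changes made so far has moved the read-out outside the usual scatter.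

Within the data shown here, the expectation for compound 4 rests on a single precedent, the step from compound 2 to compound 1, which is no change at the digits printed from compound 2 to compound 1 (within the scatter); with only one such pair, and with the core of compound 3 carrying a different benzyl group on the amine side, the precedent is thin, but nothing among the measured compounds points to a shift. On that basis the step from compound 3 to compound 4 in this assay is expected to be no change at the digits printed from compound 3 to compound 4 (within the scatter), matching the earlier one. Compound 4 is therefore estimated at 23 10^-6 cm/s in this assay. For compound 4 the expected range is 12 10^-6 cm/s to 45 10^-6 cm/s.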

Compound 4, apparent permeability: 23 10^-6 cm/s
The estimate for compound 4 equals the measured number at the digits printed; the measured number falls inside the stated range.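

In this assay, 2-chloro-4-fluorophenyl in place of cyclohexyl gives no change at the digits printed from compound 3 to compound 4 (within the scatter), and this agrees with the same change on the other core: the same change on two cores in this assay, no change at the digits printed (within the scatter) from compound 2 to compound 1 and no change at the digits printed (within the scatter) from compound 3 to compound 4, 1.0-fold (0.00 log units) apart, within the scatter of two such steps

2-hydroxy-3-methoxyphenyl in place of 5-fluoro-2-methoxyphenyl gives no change at the digits printed from compound 1 to compound 4 (within the scatter), and this also agrees with the same change on the other core: the same change on two cores in this assay, no change at the digits printed (within the scatter) from compound 2 to compound 3 and no change at the digits printed (within the scatter) from compound 1 to compound 4, 1.0-fold (0.00 log units) apart, within the scatter of two such steps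

Among these compounds, the four compounds thus complete a square in which each change reads the same on both cores, but since every step is flat, this shows only that neither change moves the read-out on these two cores, and it does not test whether a step of real size would carry from one core to the other.

Still open, going by these compounds, is whether the read-out in this assay stays level with a carboxylic acid or a morpholine on the saturated chain carbon bound to an aromatic carbon, or with a longer chain carrying the amine nitrogen. Such compounds could show whether the two cores still read alike once a change moves the read-out beyond the usual scatter.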